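The compounds below may be only part of what the source reports. "The series", "measured", "known", "first", "only" and "open" are said of these compounds alone.

Among the compounds with values here, compound 1, `COc1ccc(NC(=O)Nc2cc(C)nc3ccccc23)cc1`, is the parent of this small set and gives 787 10^-6 cm/s in an ADME assay for permeability, using PAMPA, at pH 7.4 (a higher number here means that the compound crosses the layer faster, a lower number that the compound crosses the layer more slowly), the highest of the three numbers so far. Compound 2, `COc1ccc(NC(=O)Nc2cc(C)nc3ccccc23)cc1F`, carries fluoro in place of hydrogen on an aromatic carbon and gives 50 10^-6 cm/s, so that a 16-fold lower number from compound 1 to compound 2 (1.20 log units; beyond the scatter). Compound 3, `COc1ccc(NC(=O)Nc2cc(C)nc3ccccc23)cc1Cl`, carries chloro in place of hydrogen on an aromatic carbon and gives 336 10^-6 cm/s, so that a 2.3-fold lower number from compound 1 to compound 3 (0.37 log units; beyond the scatter); between the two halogens, a 6.7-fold higher number from compound 2 to compound 3 (0.83 log units; beyond the scatter).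

Compound 4, `Cc1cc(NC(=O)Nc2ccc(OC(F)(F)F)cc2)c2ccccc2n1`, differs from compound 1 in a different place: trifluoromethyl in place of methyl on an oxygen on an aromatic ring. Within the data shown here, no measured step touches this oxygen, so the halogen steps on the aromatic carbon are the only guide, and both point downward from compound 1, one large and one modest. Since the change in compound 4 sits elsewhere and adds fluorines only within the trifluoromethyl, a step of modest size downward, or none beyond the scatter, is expected: compound 4 is estimated at 400 10^-6 cm/s, within 150 10^-6 cm/s to 800 10^-6 cm/s, which would mean a 2.0-fold lower number from compound 1 to compound 4 (0.29 log units; within the scatter).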

Compound 4, apparent permeability: 531 10^-6 cm/s
The estimate for compound 4 lay 1.3-fold (0.12 log units) below the measured number, and the stated range covers the measured number.
By their numbers in this assay, from the lowest: compound 2; then compounds 3, 4 and 1 (each within the scatter of the next, the first and the last beyond it).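

In this assay, the oxygen on the aromatic ring now has a step of its own: trifluoromethyl in place of methyl leaves the number within the scatter (a 1.5-fold lower number from compound 1 to compound 4 (0.17 log units; within the scatter)). Within the data shown here, this is the first step in the set that stays within the scatter, whereas the two steps on the aromatic carbon lie beyond it (a 16-fold lower number from compound 1 to compound 2 (1.20 log units; beyond the scatter); a 2.3-fold lower number from compound 1 to compound 3 (0.37 log units; beyond the scatter)), so the halogen steps do not carry over to this change on the oxygen. No measurement at hand explains the small size of this step.

The compounds shown carry only methyl and trifluoromethyl on this oxygen, so the outcome with an ethyl group or a longer chain there, or with an amine in place of the oxygen, stays open. Also open, from the compounds shown here alone, is whether fluoro or chloro on the aromatic carbon gives the same steps when trifluoromethyl sits on the oxygen.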